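A few compounds are considered here, and "the series" means these few. Any claim that something is new, unique, unknown or untested is made for them only; others in the source may bear on it.

The two measured compounds:
compound 1, `CC(C)C(=O)OCOC(=O)N1CCN(C(=O)c2nc(Nc3cc(C4CC4)[nH]n3)c3cc(Cl)ccc3n2)C[C@H]1C`, with 16.4% in an assay for inhibition of serine/threonine-protein kinase PAK 4 (Homo sapiens), read by FRET and Z'-LYTE, with a stated time of 60 min, tested at 0.5 uM, in the presence of a further agent that is not named here; a lower number here means a weaker effect, a higher number a stronger effect of the compound at the concentration tested;
compound 2, `C[C@@H]1CN(C(=O)c2nc(Nc3cc(C4CC4)[nH]n3)c3cc(Cl)ccc3n2)CCN1C(=O)OC(C)(C)C`, with 0.1%.

Compound 2 stands lowest of the two numbers in this assay, and its nearest neighbour is compound 1. For the measured compounds named here, the only measured step, a number 16.3 percentage points lower from compound 1 to compound 2 (beyond the scatter), lies beyond the scatter and is the one that bears here. Compound 3, `CC(OC(=O)N1CCN(C(=O)c2nc(Nc3cc(C4CC4)[nH]n3)c3cc(Cl)ccc3n2)C[C@H]1C)OC(=O)C(C)(C)C`, follows from compound 2 by 1-(((tert-butyl)carbonyl)oxy)ethyl in place of tert-butyl on an oxygen next to a carbonyl group, which undoes the tert-butyl of that earlier step. Compound 3 is therefore expected to rise, with a number 13.9 percentage points higher from compound 2 to compound 3 (beyond the scatter), and is estimated at 14%, in a range from 2% to 30%.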

Compound 3, a percentage reported as inhibition, at one concentration (the size of the read-out at that concentration, not a potency): -6.9%
Compound 3: middle estimate off by 20.9 percentage points, on the high side; the measured number lies below the stated range.
By their numbers in this assay, from the lowest: compounds 3 and 2 (each within the scatter of the next); then compound 1.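

In this assay, the two groups that carry a second carbonyl on the oxygen next to a carbonyl group do not read alike: a number 23.3 percentage points lower from compound 1 to compound 3 (beyond the scatter). The 1-(((tert-butyl)carbonyl)oxy)ethyl group thus does not recover the number of compound 1, and a number 7 percentage points lower from compound 2 to compound 3 (within the scatter), leaving compound 3 indistinguishable from compound 2. No measurement shown here accounts for this difference.

On these data alone, what remains open is whether the gap between compound 1 and compound 3 tracks the ethyl link or the tert-butyl end. As far as these compounds go, how a plain methyl group on that oxygen would read also remains open.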